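The source may hold more compounds than are shown below. What is called first, only, known or untested is meant among the compounds shown, and "the series" means these compounds.

Series notes. Of the compounds shown here, three have been measured in a physicochemical assay for lipophilicity, using the shake flask method, measured as octanol-water partition, at pH 7.4; on this read-out lower numbers stand for lower lipophilicity and higher numbers for higher lipophilicity. Compound 1 `CCN(CC)CCCCCCCCOc1ccc(/C=C/C(=O)Nc2ccccc2)cc1OC` gives 1.75, the lowest of the three numbers, though the others lie within the scatter of it: compound 2 `CCN(CC)CCCCCCCCCCOc1ccc(/C=C/C(=O)Nc2ccccc2)cc1OC` gives 1.83 and compound 3 `COc1cc(/C=C/C(=O)Nc2ccccc2)ccc1OCCCCCCCCCCN1CCCC1` gives 1.86, with a number 0.08 log units higher from compound 1 to compound 2 (within the scatter), a number 0.11 log units higher from compound 1 to compound 3 (within the scatter) and a number 0.03 log units higher from compound 2 to compound 3 (within the scatter). All three steps alter only the amine end of the chain. Compound 4 `CCN(CC)CCCCCCCCOc1ccc(/C=C/C(=O)O)cc1OC` differs from compound 1 at the other end: hydroxy in place of anilino on a carbonyl carbon. For the measured compounds named here, no measured step touches the carbonyl carbon, so the three within-scatter steps bear nothing on this one; the expectation rests on the change itself, which removes the anilino ring. Compound 4 is expected to come out well below compound 1 in this assay, by a number 2.25 log units lower from compound 1 to compound 4 (beyond the scatter), at an estimated -0.5 with a range from -1.5 to 0.5.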

Compound 4, partition coefficient: 1.51
Beside the measured number, compound 4's estimate is 2.01 log units below it, and the stated range ends below it.
By their numbers in this assay, from the lowest: compounds 4, 1, 2 and 3 (each within the scatter of the next, the first and the last beyond it).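

Hydroxy in place of anilino on a carbonyl carbon gives a number 0.24 log units lower from compound 1 to compound 4 (within the scatter) in this assay and so extends the within-scatter picture from the amine end of the chain to this position. Even this exchange, which takes away the six-membered aromatic ring, does not separate compound 4 from compound 1. No available evidence explains this result.

On these data alone, a methyl ester or primary amide in place of anilino on this carbonyl carbon remains open. So does the same exchange on the longer chain of compound 2.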